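The compounds below may be only part of what the source reports. "The series", "measured", "known", "first", "only" and "open" are said of these compounds alone.

Measured in a functional assay on MV4-11 cells (Homo sapiens) for inhibition, read by resazurin assay, with a stated time of 72 h; a lower number here means a stronger inhibitor of growth, a higher number a weaker inhibitor of growth:
- Compound 1 `CCn1cc(-c2ccnc(Nc3ccc(OC)cc3OC)n2)c2ccccc21`: 3590 nM
- Compound 2 `COc1ccc(Nc2nccc(-c3cn(C)c4ccccc34)n2)c(OC)c1`: 3410 nM

For the measured compounds named here, with only two numbers in hand, compound 2 has a single neighbour, compound 1, and the two values lie within the scatter of each other, so neither can be ranked ahead. The next molecule, compound 3 `COc1ccc(Nc2nccc(-c3cn(C(C)C)c4ccccc34)n2)c(OC)c1`, keeps the core of compound 2 and alters one group: isopropyl in place of methyl on an aromatic nitrogen. Put simply, this is isopropyl in place of methyl on an aromatic nitrogen.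

Going by the values given here, one measured step bears on this, since it also alters the group on that nitrogen: a 1.1-fold lower number from compound 1 to compound 2 (0.02 log units; within the scatter). That step stayed within the scatter, so trimming this group changed nothing measurable in that pair. Among the compounds with values here, it is only a loose guide, as no compound with isopropyl has been measured yet. The expectation in this assay is therefore for no change beyond the scatter, in either direction. The expected step is a 1.0-fold higher number from compound 2 to compound 3 (0.01 log units; within the scatter). For compound 3 the estimated value is 3500 nM, with an expected range of 1500 nM to 8000 nM.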

Compound 3, concentration for 50% growth inhibition: 3250 nM
Compound 3: the middle estimate sits 1.1-fold (0.03 log units) above what was measured; the range from low to high includes it.
By their numbers in this assay, from the lowest: compounds 3, 2 and 1 (each within the scatter of the next).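

Two changes lead to compound 3 in this assay: isopropyl in place of methyl on the aromatic nitrogen (a 1.0-fold lower number from compound 2 to compound 3 (0.02 log units; within the scatter)), and methyl in place of hydrogen on the saturated chain carbon bound to that nitrogen (a 1.1-fold lower number from compound 1 to compound 3 (0.04 log units; within the scatter)). The earlier pair tested only a small extension of the group on this nitrogen, whereas compound 3 carries isopropyl, with 3 heavy atoms against the 1 of methyl, and its value still lies within the scatter of both neighbours, so this assay cannot separate the three compounds. No measurement is at hand that would explain why these values sit so close together.

Going by these compounds, all three groups on this nitrogen are small and made only of carbon and hydrogen, so it remains open whether a plain hydrogen, a longer chain, a benzyl group, or a chain ending in an amine or a carboxylic acid would also stay within the scatter. The rest of the molecule is the same throughout. These compounds say nothing about how the two methoxy groups on the other aromatic ring affect growth inhibition.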